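Replacing a two-ring group with phenyl in compound 2

The source may hold more compounds than are shown below. What is called first, only, known or untested is meant among the compounds shown, and "the series" means these compounds.

Compound 1 `COc1ccc(CN(C(=O)Cn2cc(COc3cc(=O)oc4ccccc34)nn2)c2cc(OC)c(OC)c(OC)c2)cc1`: 3660 nM
Compound 2 `COc1ccc(CN(C(=O)Cn2cc(COc3ccc4c(C)cc(=O)oc4c3)nn2)c2cc(OC)c(OC)c(OC)c2)cc1`: 130 nM

In a functional assay on MGC-803 cells (Homo sapiens) for antiproliferative activity, read by MTT assay, with a stated time of 48 h (a higher number here means a weaker inhibitor, a lower number a stronger inhibitor), compound 2 has the lower of the two numbers, 130 nM, so it is the stronger inhibitor. Compound 3 `COc1ccc(CN(C(=O)Cn2cc(COc3ccccc3)nn2)c2cc(OC)c(OC)c(OC)c2)cc1` differs from compound 2 by a group of 6 heavy atoms (6 carbon; one six-membered aromatic ring of carbon only) in place of a group of 12 heavy atoms (10 carbon, 2 oxygen; one six-membered aromatic ring of carbon only, one six-membered aromatic ring with 1 hetero atom), on an oxygen on a saturated carbon. Going by the values given here, the only measured step, a 28-fold lower number from compound 1 to compound 2 (1.45 log units; beyond the scatter), is large and alters the group at this same place. On these data alone, that group therefore seems able to shift the number strongly, though phenyl itself is untested here. A large move to a higher number is expected, an estimated step of a 31-fold higher number from compound 2 to compound 3 (1.49 log units; beyond the scatter). The estimate for compound 3 is 4000 nM, with an expected range from 1000 nM to 20000 nM.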

Compound 3, half-maximal inhibitory concentration: 12500 nM
Estimate against measurement, compound 3: 3.1-fold (0.49 log units) below; measured number inside the range.
By their numbers in this assay, from the lowest: compound 2; then compound 1; then compound 3.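

In this assay, replacing the two-ring group on this oxygen with phenyl gives a 96-fold higher number from compound 2 to compound 3 (1.98 log units; beyond the scatter), so a single ring falls far short of that group. The same replacement gives only a 3.4-fold higher number from compound 1 to compound 3 (0.53 log units; beyond the scatter), so the size of the change depends on which two-ring group leaves, not merely on losing a second ring. Nothing measured here explains this difference.

Still open, on these data alone, is whether a naphthyl group on this oxygen would approach compound 2, or whether phenyl carrying a methoxy or an amine would improve on compound 3.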